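Carbonyl-side aryl swap on the shared pyrazole-amide core

The source may report more compounds than this note shows. Statements on the series, on what has been measured and on what is new or still open speak of the compounds shown alone.

Compound 1 `O=C(Nc1cc(-c2ccccc2)nn1-c1ccccc1)c1ccc(F)cc1` gives 30 nM in an assay on CHO cells with metabotropic glutamate receptor 5 (Homo sapiens) as the target (a higher number here means that more compound is needed for the effect, a lower number that less compound is needed), the lowest of the three numbers on record. Compound 2 `O=C(Nc1cc(-c2ccccc2)nn1-c1ccccc1)c1ccccn1` gives 290 nM and compound 3 `O=C(Nc1cc(-c2ccccc2)nn1-c1ccccc1)c1cnccn1` gives 200 nM in this assay. Compound 4 `Cc1cccc(C(=O)Nc2cc(-c3ccccc3)nn2-c2ccccc2)c1` differs from compound 1 by 3-methylphenyl in place of 4-fluorophenyl on a carbonyl carbon. The measured steps that bear on this position are a 9.7-fold higher number from compound 1 to compound 2 (0.99 log units; beyond the scatter) and a 6.7-fold higher number from compound 1 to compound 3 (0.82 log units; beyond the scatter); both replace the ring with a nitrogen-containing one and both rise modestly, while a 1.5-fold lower number from compound 2 to compound 3 (0.16 log units; within the scatter) stays within the scatter. Compound 4 keeps a ring of carbon only, so neither step speaks directly to it; a shift of at most modest size, in either direction, is expected. Compound 4 is therefore estimated at 50 nM (range 15 nM to 200 nM), which would mean a 1.7-fold higher number from compound 1 to compound 4 (0.22 log units; within the scatter).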

Compound 4, half-maximal effective concentration: 90 nM
Compound 4: the middle estimate sits 1.8-fold (0.26 log units) below what was measured; low and high end bracket the measured number.
By their numbers in this assay, from the lowest: compound 1; then compound 4; then compounds 3 and 2 (each within the scatter of the next).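

Keeping a ring of carbon only at this position does not preserve the number of compound 1, as 3-methylphenyl in place of 4-fluorophenyl gives a 3.0-fold higher number from compound 1 to compound 4 (0.48 log units; beyond the scatter) in this assay. That ring still stays below both nitrogen-containing rings, with a 2.2-fold lower number from compound 3 to compound 4 (0.35 log units; beyond the scatter) and a 3.2-fold lower number from compound 2 to compound 4 (0.51 log units; beyond the scatter) on the carbonyl carbon. No available evidence explains these shifts.

The shown compounds do not separate losing the fluorine from adding the methyl, which plain phenyl on the carbonyl carbon could begin to resolve. On these data alone, how a ring bearing an amine or a carboxylic acid would read here remains open.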